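A few compounds are considered here, and "the series" means these few. Any claim that something is new, unique, unknown or untested is made for them only; others in the source may bear on it.

The study measures inhibition of cell growth in a functional assay on K562 cells (Homo sapiens), read by MTT assay, with a stated time of 72 h; a higher number here means a weaker inhibitor, a lower number a stronger inhibitor. Compound 1, `C#Cc1cn([C@@H]2O[C@H](CO)[C@@H](O)[C@H]2O)c2ncnc(OC)c12`, carries an ethynyl group and a methoxy group on its core, and in this assay compound 1 gives 380 nM. Compound 2, `O=c1[nH]cnc2c1c(-c1cc3ccccc3o1)cn2[C@@H]1O[C@H](CO)[C@@H](O)[C@H]1O`, has a different core and a 1-benzofuran-2-yl group. For compound 2 only a limit is recorded in this assay, namely > 20000 nM. Among the measured compounds shown here, this places compound 2 at the limit of > 20000 nM in this assay, at which 1 of the 2 values shown sits, so its true potency is not known beyond that point, and no step from compound 1 can be sized.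

Compound 3, `O=c1[nH]cnc2c1c(-c1ccoc1)cn2[C@@H]1O[C@H](CO)[C@@H](O)[C@H]1O`, differs from compound 2 by furan-3-yl in place of 1-benzofuran-2-yl on an aromatic carbon. For the measured compounds named here, with compound 2 known only as a limit, the size of the step cannot be judged from a measured pair, and no other pair in the set shows what this change does. The expectation is that compound 3 remains weak in this assay, most likely again reported as a limit, with the step of a number no higher from compound 2 to compound 3 (the limit leaves the size open) expected to be small. Compound 3 is therefore estimated at 20000 nM, between 5000 nM and 60000 nM.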

Compound 3, half-maximal inhibitory concentration: 14500 nM
For compound 3 the middle estimate is 1.4-fold (0.14 log units) above the measured one; the measured number falls inside the stated range.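

In this assay, among the compounds shown here, compound 3 gives 14500 nM, which is the first reading on this core that is a number and not a limit, with furan-3-yl on the aromatic carbon two ring bonds from the ring nitrogen. Replacing 1-benzofuran-2-yl with furan-3-yl at this position amounts to an at least 1.3-fold lower number from compound 2 to compound 3 (0.13 log units; that floor lies within the scatter), and this floor alone does not establish a real gain in potency. The step can be stated only as a floor because the value for compound 2 is a limit: the limit of > 20000 nM in this assay, at which 1 of the 3 values shown sits.

The compounds shown leave open how this position would respond to a different kind of group, such as an amine, a carboxylic acid or a longer alkyl chain, and whether furan-2-yl would read differently from furan-3-yl. Compound 1 differs from compound 3 in more than one place, and the separate contributions of its ethynyl and methoxy groups to its much lower number remain unresolved.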